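A Fluorine for Chlorine Swap at the Terminal Aryl

A few compounds are considered here, and "the series" means these few. Any claim that something is new, unique, unknown or untested is made for them only; others in the source may bear on it.

Of the compounds shown here, three sharing one core have been measured in a functional assay on L1210 cells (Mus musculus) for inhibition, read by MTT assay, with a stated time of 72 h; on this read-out higher numbers stand for weaker inhibition and lower numbers for stronger inhibition. Compound 1 `COc1cc(NC(C)CCCNC(=O)Nc2ccc(C(F)(F)F)cc2)c2ncccc2c1` gives 7400 nM. Compound 2 `COc1cc(NC(C)CCCNC(=O)Nc2ccc(O)cc2)c2ncccc2c1` gives 21000 nM. Compound 3 `COc1cc(NC(C)CCCNC(=O)NNC(=O)Nc2cccc(Cl)c2)c2ncccc2c1` gives 27000 nM. On these numbers compound 3 stands highest: the step of a 3.6-fold higher number from compound 1 to compound 3 (0.56 log units; beyond the scatter) lies beyond the scatter, while the step of a 1.3-fold higher number from compound 2 to compound 3 (0.11 log units; within the scatter) does not, so compounds 2 and 3 cannot be told apart on this read-out.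

Compound 4 `COc1cc(NC(C)CCCNC(=O)NNC(=O)Nc2ccc(F)cc2)c2ncccc2c1` differs from compound 3 in one place: 4-fluorophenyl in place of 3-chlorophenyl on an amide-type nitrogen. Going by the values given here, no measured step changes exactly this part of the molecule. The nearest comparison is the step of a 2.8-fold higher number from compound 1 to compound 2 (0.45 log units; beyond the scatter), where one substituent on the terminal aryl ring was exchanged for another and the number moved modestly. The present exchange keeps the aryl ring and replaces one halogen by another, so a step of similar or smaller size is expected, in either direction, and most likely within the scatter.

Compound 4 is therefore expected to give about 25000 nM in this assay, within the range 10000 nM to 60000 nM, which corresponds to an expected step of a 1.1-fold lower number from compound 3 to compound 4 (0.03 log units; within the scatter).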

Compound 4, half-maximal inhibitory concentration: 104000 nM
Beside the measured number, compound 4's estimate is 4.2-fold (0.62 log units) below it; the whole stated range lies below it.
By their numbers in this assay, from the lowest: compound 1; then compounds 2 and 3 (each within the scatter of the next); then compound 4.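

The exchange of 3-chlorophenyl for 4-fluorophenyl on an amide-type nitrogen is not silent in this assay: it gives a 3.9-fold higher number from compound 3 to compound 4 (0.59 log units; beyond the scatter), so this terminal aryl group matters even when one halogen-bearing phenyl replaces another. Compound 4 also separates from the other two compounds, with a 5.0-fold higher number from compound 2 to compound 4 (0.69 log units; beyond the scatter) and a 14-fold higher number from compound 1 to compound 4 (1.15 log units; beyond the scatter), the latter being the only large step shown, and it gives the weakest inhibition of the four. Nothing available here accounts for the size of this shift.

Because 3-chlorophenyl and 4-fluorophenyl differ in both the halogen and its place on the ring, the compounds shown cannot separate those two changes. As far as these compounds go, whether 4-chlorophenyl or 3-fluorophenyl would sit nearer compound 3 or compound 4 stays open, as does the outcome with an amine or a carboxylic acid on the terminal ring.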